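The source may report more compounds than this note shows. Statements on the series, on what has been measured and on what is new or still open speak of the compounds shown alone.

Measured so far in a functional assay on MDA-MB-231 cells (Homo sapiens) for antiproliferative activity, read by MTT assay, with a stated time of 24 h; on this read-out lower numbers stand for stronger inhibition and higher numbers for weaker inhibition:
- compound 1 `O=C(NNc1ccccc1F)c1ccc(NS(=O)(=O)c2cnc(O)nc2O)cc1`: > 20000 nM
- compound 2 `O=C(NNc1ccc(F)cc1)c1cccc(NS(=O)(=O)c2cnc(O)nc2O)c1`: > 20000 nM
- compound 3 `Cc1ccccc1NNC(=O)c1ccccc1NS(=O)(=O)c1cnc(O)nc1O`: > 20000 nM

Compound 1 gives no actual number in this assay: its > 20000 nM is a limit of the assay. Compound 2 and compound 3 share that position, and the whole measured set comes down to the limit of > 20000 nM in this assay, at which 3 of the 3 values shown sit. Among the compounds with values here, no measured pair yet shows how a structural change moves the result.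

Compound 4 `O=C(NNC(=O)c1ccc(NS(=O)(=O)c2cnc(O)nc2O)cc1)c1ccc(F)cc1` keeps the core of compound 1 and changes one group on an amine nitrogen whose other neighbour is an amide-type nitrogen: (4-fluorophenyl)carbonyl in place of 2-fluorophenyl on an amine nitrogen. A carbonyl therefore now stands where the ring was directly attached.

The expectation rests on compound 1, whose > 20000 nM is a limit, and on the absence of any measured number in the set. No change beyond the usual scatter is expected, so the estimated move is a number no higher from compound 1 to compound 4 (the limit leaves the size open). For compound 4 the estimated value is 20000 nM, with an expected range from 6000 nM to 40000 nM.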

Compound 4, half-maximal inhibitory concentration: > 20000 nM
Compound 4 was reported as a limit; the forecaster's own chance of this, stated with the estimate: 65%; the middle value lies on the limit itself.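

Compound 1 and compound 4 each give only a limit of the assay, not a number, so no step can be read between them, and the set stays at one limit: the limit of > 20000 nM in this assay, at which 4 of the 4 values shown sit. The compounds shown leave open which structural change, if any, gives a real number in this assay.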